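The source may hold more compounds than are shown below. What is called first, only, known or untested is meant among the compounds shown, and "the series" means these compounds.

Compound 3 `O=C(O)/C=C/C(=O)Nc1cccc(-c2nc3ccccc3s2)c1` gives 56000 nM in a physicochemical assay for solubility, in phosphate buffer, measured as kinetic solubility, with a stated time of 18 h, at pH 7.4 (a lower number here means a less soluble compound, a higher number a more soluble compound), the highest of the three values here. Compound 2 `C=CC(=O)Nc1cccc(-c2nc3ccccc3s2)c1` gives 180 nM, and compound 1 `O=C(Nc1ccc(Cl)cc1)c1cc([N+](=O)[O-])ccc1Cl` gives 3000 nM. Among the measured compounds shown here, the single measured step, a 310-fold higher number from compound 2 to compound 3 (2.49 log units; beyond the scatter), came with 2-carboxyethenyl in place of vinyl on a carbonyl carbon. Compound 4 `O=C(Nc1cccc(-c2nc3ccccc3s2)c1)c1cnccc1Cl` takes the opposite road: 4-chloropyridin-3-yl in place of 2-carboxyethenyl on a carbonyl carbon. The acid that accompanied the large rise from compound 2 to compound 3 is gone, and a second aromatic ring is added, so a large fall in this assay is expected, as in a 110-fold lower number from compound 3 to compound 4 (2.05 log units; beyond the scatter), with the number likely landing between those of compound 2 and compound 1. Compound 4 is therefore estimated at 500 nM, within a range of 100 nM to 3000 nM.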

Compound 4, solubility: 320 nM
For compound 4 the middle estimate is 1.6-fold (0.19 log units) above the measured one; measured number inside the range.
By their numbers in this assay, from the lowest: compounds 2 and 4 (each within the scatter of the next); then compound 1; then compound 3.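

On this carbonyl carbon, 4-chloropyridin-3-yl in place of 2-carboxyethenyl gives a 180-fold lower number from compound 3 to compound 4 (2.24 log units; beyond the scatter) and so does not keep the high number of compound 3. Set against vinyl, the same ring gives a 1.8-fold higher number from compound 2 to compound 4 (0.25 log units; within the scatter) in this assay and so reads alike despite the added ring, leaving 2-carboxyethenyl alone apart among these three groups. No evidence is available to explain either step. From the compounds shown here alone, it remains open whether a saturated chain ending in a carboxylic acid would match compound 3 on this carbonyl carbon. Also open, going by these compounds, is whether an amine on the pyridine ring would lift the number of compound 4 in this assay at all.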